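Ether swap: pyridin-2-yl to phenyl on the shared core

A few compounds are considered here, and "the series" means these few. Any claim that something is new, unique, unknown or untested is made for them only; others in the source may bear on it.

The series shares one core carrying a butylamino group and an ether; the compounds differ only in the group on the ether oxygen. Compound 1 `CCCCNc1nc(N)nnc1OC(C)C` carries a small branched alkyl ether; in an assay on isolated protein for agonist activity at Toll-like receptor 8 (Homo sapiens) (on this read-out higher numbers stand for an effect only at larger amounts of compound and lower numbers for an effect already at smaller amounts), compound 1 gives 460 nM. Compound 2 `CCCCNc1nc(N)nnc1OCc1ccccn1` carries a pyridin-2-ylmethyl ether; in this assay compound 2 gives 330 nM. For the measured compounds named here, compound 2 holds the lowest of the two numbers so far, but its gap to compound 1 lies within the scatter, so no order between the two can be read from these values.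

Compound 3 `CCCCNc1nc(N)nnc1OCc1ccccc1` is the next compound and has not been measured. It differs from compound 2 as follows: phenyl in place of pyridin-2-yl on a saturated chain carbon bound to an oxygen on an aromatic ring. Going by the values given here, no step between measured compounds is available to anchor this change; the single measured pair shows only that two rather different ether groups land close together. The step from compound 2 to compound 3 in this assay is therefore expected to be small, in either direction, likely not beyond the scatter: a 1.1-fold higher number from compound 2 to compound 3 (0.03 log units; within the scatter). Compound 3 is estimated at 350 nM, with a range from 150 nM to 900 nM.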

Compound 3, half-maximal effective concentration: 1930 nM
Estimate against measurement, compound 3: 5.5-fold (0.74 log units) below, and the stated range ends below it.
By their numbers in this assay, from the lowest: compounds 2 and 1 (each within the scatter of the next); then compound 3.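

In this assay, the ether group is not indifferent to a small change: a 5.8-fold higher number from compound 2 to compound 3 (0.77 log units; beyond the scatter) accompanies phenyl in place of pyridin-2-yl on a saturated chain carbon bound to an oxygen on an aromatic ring, although both groups are six-membered aromatic rings with the same heavy-atom count. The earlier pair could not show this, as compound 1 and compound 2 carry rather different ether groups yet lie within the scatter of each other, whereas compound 3 has the highest number of the three at 1930 nM. Nothing measured here accounts for the step, so the exchange of a ring nitrogen for carbon and the loss of a hydrogen-bond acceptor stand only as structural differences between the two compounds.

Open, as far as these compounds go, is whether the number of compound 2 depends on the ring nitrogen specifically, which a pyrimidinyl group, or an amine or hydroxyl on the phenyl ring, would help to test. Also open, from the compounds shown here alone, is whether the step from pyridin-2-yl to phenyl holds when a longer chain replaces the butyl of the butylamino group.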